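Acyl variation at the pyrrolidine nitrogen of compound 3

A few compounds are considered here, and "the series" means these few. Any claim that something is new, unique, unknown or untested is made for them only; others in the source may bear on it.

Measured compounds in an assay on isolated protein for binding affinity to secreted frizzled-related protein 1 (Homo sapiens), read by fluorescence; on this read-out higher numbers stand for weaker inhibition and lower numbers for stronger inhibition:
compound 1, `O=C(CN1CCNCC1)N1CCC(NS(=O)(=O)c2cc(S(=O)(=O)c3ccccc3)ccc2C(F)(F)F)CC1`: 140 nM
compound 2, `O=C1CC[C@@H](C(=O)N2CCC(NS(=O)(=O)c3cc(S(=O)(=O)c4ccccc4)ccc3C(F)(F)F)CC2)N1`: 90 nM
compound 3, `CC(C)C(=O)N1CCC[C@H]1C(=O)N1CCC(NS(=O)(=O)c2cc(S(=O)(=O)c3ccccc3)ccc2C(F)(F)F)CC1`: 40 nM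

Compound 3 gives the lowest number of the three. The steps of a 3.5-fold lower number from compound 1 to compound 3 (0.54 log units; beyond the scatter) and a 2.3-fold lower number from compound 2 to compound 3 (0.35 log units; beyond the scatter) both lie beyond the scatter, whereas a 1.6-fold lower number from compound 1 to compound 2 (0.19 log units; within the scatter) lies within it. All three measured steps vary the group on the carbonyl carbon that carries the (piperazin-1-yl)methyl, 5-oxopyrrolidin-2-yl or 1-(isopropylcarbonyl)pyrrolidin-2-yl group.

Compound 4, `CN(C)c1ccc(C(=O)N2CCC[C@H]2C(=O)N2CCC(NS(=O)(=O)c3cc(S(=O)(=O)c4ccccc4)ccc3C(F)(F)F)CC2)cc1`, differs from compound 3 in one place: 4-(dimethylamino)phenyl in place of isopropyl on a carbonyl carbon. Within the data shown here, this position is not touched by any measured step, so no step bears directly on it. Among the measured compounds shown here, the only guide is that compound 3 already tolerates an acyl group at this nitrogen, giving 40 nM, and the data give no sign of how a larger acyl group would read. With nothing measured on this side of the molecule, the expectation defaults to no step beyond the scatter, held with a wide range.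

Compound 4 is therefore expected to give about 40 nM in this assay, within 15 nM to 110 nM. The step of no change at the digits printed from compound 3 to compound 4 (within the scatter) is estimated to stay within the scatter.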

Compound 4, half-maximal inhibitory concentration: 110 nM
Beside the measured number, compound 4's estimate is 2.8-fold (0.44 log units) below it; the measured number falls inside the stated range.
By their numbers in this assay, from the lowest: compound 3; then compounds 2, 4 and 1 (each within the scatter of the next).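

In this assay, among these compounds, a 2.8-fold higher number from compound 3 to compound 4 (0.44 log units; beyond the scatter) shows that the group on the carbonyl carbon whose other neighbour is the amide-type nitrogen in a ring is not a silent position: the reading responds to what is placed there, a point the earlier steps could not address since they all varied a different part of the molecule. The response is moderate, and compound 4 with its 4-(dimethylamino)phenyl group still reads 110 nM, so this position accepts a group of 9 heavy atoms with an aromatic ring in place of the 3 heavy atoms of isopropyl, at some cost in the number. The step changes size, ring and hydrogen-bond acceptor count all at once, and no supporting data on the origin of the shift are available.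

Still open, from the compounds shown here alone, is whether the aromatic ring or the dimethylamino group accounts for the step, a question that plain phenyl or cyclohexyl in the same place would help to separate. Equally open, going by these compounds, is how this position reads with an acyl group smaller than isobutyryl, such as acetyl, or with a carboxylic acid on the phenyl ring.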